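Moving the carboxyl on compound 2's phenyl ring

The source may report more compounds than this note shows. Statements on the series, on what has been measured and on what is new or still open speak of the compounds shown alone.

Measured in a physicochemical assay for solubility; a lower number here means a less soluble compound, a higher number a more soluble compound:
Compound 1 `O=C(c1cccc(Cl)c1)N1CCC(NS(=O)(=O)c2cc(S(=O)(=O)c3ccccc3)ccc2C(F)(F)F)CC1`: 6300 nM
Compound 2 `O=C(O)c1cccc(S(=O)(=O)N2CCC(NS(=O)(=O)c3cc(S(=O)(=O)c4ccccc4)ccc3C(F)(F)F)CC2)c1`: 12500 nM

Among the measured compounds shown here, the only measured step is a 2.0-fold higher number from compound 1 to compound 2 (0.30 log units; within the scatter). For the measured compounds named here, that leaves compound 2 within the scatter of its single comparator, so the series so far shows no separation on these numbers. Compound 3 `O=C(O)c1ccc(S(=O)(=O)N2CCC(NS(=O)(=O)c3cc(S(=O)(=O)c4ccccc4)ccc3C(F)(F)F)CC2)cc1` has the same atoms as compound 2, joined differently, and the change falls on a sulfonyl sulfur: 4-carboxyphenyl in place of 3-carboxyphenyl on a sulfonyl sulfur. Going by the values given here, no measured step shows this kind of move. Among the compounds with values here, the one available step exchanged a whole (3-chlorophenyl)carbonyl for (3-carboxyphenyl)sulfonyl, so it offers only loose guidance. With compound 2 at 12500 nM as the anchor, no change beyond the scatter is expected. The expected step is no change at the digits printed from compound 2 to compound 3 (within the scatter). For compound 3 the estimated value is 12500 nM, with an expected range of 5500 nM to 28000 nM.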

Compound 3, solubility: 12500 nM
Compound 3: middle estimate and measured number agree at the digits printed, and the stated range covers the measured number.
By their numbers in this assay, from the lowest: compounds 1, 2 and 3 (each within the scatter of the next).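

In this assay, among the compounds shown here, moving the carboxyl from 3-carboxyphenyl to 4-carboxyphenyl on a sulfonyl sulfur gives no change at the digits printed from compound 2 to compound 3 (within the scatter), the first reading of this position alone, since the earlier step had exchanged a whole group. The exchange of (3-chlorophenyl)carbonyl for (4-carboxyphenyl)sulfonyl gives a 2.0-fold higher number from compound 1 to compound 3 (0.30 log units; within the scatter), so these two carboxyphenyl isomers do not separate on these numbers, either from each other or from compound 1. No supporting measurement bears on this result.

The compounds shown leave open whether a methyl ester or an amine in place of the carboxylic acid on this ring would read any differently. Both exchanges from compound 1 also alter the carbonyl and the ring substituent together, so the part played by each cannot be read separately.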